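The source may report more compounds than this note shows. Statements on the series, on what has been measured and on what is new or still open speak of the compounds shown alone.

Measured compounds in an assay on isolated protein for inhibition of ubiquitin carboxyl-terminal hydrolase 7 (Homo sapiens), with stated times of 30 min and 2 h; a lower number here means a stronger inhibitor, a higher number a weaker inhibitor:
- compound 1 `Cn1nc2c(=O)n(CC3(O)CCN(Cc4ccc(-c5ccco5)cc4Cl)CC3)cnc2c1-c1ccc(C2(N)CC2)cc1` gives 66.1 nM
- compound 2 `Cn1nc2c(=O)n(CC3(O)CCN(Cc4ccc(-c5ccco5)cc4Cl)CC3)cnc2c1-c1ccc(CNS(C)(=O)=O)cc1` gives 65.3 nM
- compound 3 `CC(=O)NCc1ccc(-c2c3ncn(CC4(O)CCN(Cc5ccc(-c6ccco6)cc5Cl)CC4)c(=O)c3nn2C)cc1` gives 46.1 nM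

Compound 3 holds the lowest of the three numbers in this assay, yet its separation from compound 2 and from compound 1 stays within the scatter, so the three sit together. Compound 4 `Cn1nc2c(=O)n(CC3(O)CCN(Cc4ccc(-c5ccco5)cc4Cl)CC3)cnc2c1-c1ccc(CNC2CC2)cc1` is the next step: cyclopropyl in place of acetyl on an amine nitrogen. Among the measured compounds shown here, the closest precedent is the exchange on the same amine nitrogen, a 1.4-fold lower number from compound 2 to compound 3 (0.15 log units; within the scatter), and the other swaps at this position, a 1.0-fold lower number from compound 1 to compound 2 (0.01 log units; within the scatter) and a 1.4-fold lower number from compound 1 to compound 3 (0.16 log units; within the scatter), were likewise flat. For the measured compounds named here, no measured step tells whether removing the amide carbonyl in favour of a ring matters here. The expected outcome is therefore no change beyond the scatter, a 1.1-fold higher number from compound 3 to compound 4 (0.04 log units; within the scatter). Compound 4 is estimated at 50 nM, in the range 20 nM to 150 nM.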

Compound 4, half-maximal inhibitory concentration: 54.1 nM
Compound 4: the middle estimate sits 1.1-fold (0.03 log units) below what was measured; low and high end bracket the measured number.
By their numbers in this assay, from the lowest: compounds 3, 4, 2 and 1 (each within the scatter of the next).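

In this assay, cyclopropyl on the amine nitrogen gives no shift beyond the scatter relative to acetyl (a 1.2-fold higher number from compound 3 to compound 4 (0.07 log units; within the scatter)), so the carbonyl of the acetyl group is dispensable in this comparison. The same holds against methylsulfonyl (a 1.2-fold lower number from compound 2 to compound 4 (0.08 log units; within the scatter)) and against the 1-aminocyclopropyl compound (a 1.2-fold lower number from compound 1 to compound 4 (0.09 log units; within the scatter)), so a three-membered carbon ring is accepted here alongside the earlier groups. No available evidence accounts for this result.

On these data alone, whether a carboxylic acid, a longer alkyl chain or a morpholine ring at this position would move the number beyond the scatter remains open.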